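A few compounds are considered here, and "the series" means these few. Any claim that something is new, unique, unknown or untested is made for them only; others in the source may bear on it.

Compound 1 `FC(F)(F)c1ccc(COc2ccccc2Nc2ncnc3cc4c(cc23)OCCOCCO4)cc1` — in a functional assay on HepG2 cells (Homo sapiens) for antiproliferative activity, read by MTT assay, with a stated time of 72 h (a lower number here means a stronger inhibitor, a higher number a weaker inhibitor), compound 1 gives > 100000 nM, a limit of the assay and not a number.
Compound 2 `FC(F)(F)c1ccc(COc2cccc(Nc3ncnc4cc5c(cc34)OCCOCCO5)c2)cc1` — in this assay compound 2 gives > 100000 nM, again a limit.
Compound 3 `O=[N+]([O-])c1ccc(COc2cccc(Nc3ncnc4cc5c(cc34)OCCOCCO5)c2)cc1` — in this assay compound 3 gives 65300 nM.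

The difference between the cores of compound 1 and compound 2 is not broken down here. From compound 2 to compound 3 the change is nitro in place of trifluoromethyl on an aromatic carbon, and in this assay it gave an at least 1.5-fold lower number from compound 2 to compound 3 (0.18 log units; that floor lies within the scatter); that size rests on (the limit of > 100000 nM in this assay, at which 2 of the 3 values shown sit). Compound 4 `O=[N+]([O-])c1ccc(COc2ccccc2Nc2ncnc3cc4c(cc23)OCCOCCO4)cc1` has not yet been measured in this assay. Compound 4 differs from compound 1 by nitro in place of trifluoromethyl on an aromatic carbon, the same change at the same place. The step in this assay from compound 1 to compound 4 is expected to be an at least 1.2-fold lower number from compound 1 to compound 4 (0.09 log units; that floor lies within the scatter). That expectation rests on compound 1 standing at the limit of > 100000 nM in this assay, at which 2 of the 3 values shown sit, and on the earlier step of an at least 1.5-fold lower number from compound 2 to compound 3 (0.18 log units; that floor lies within the scatter). Compound 4 is estimated at 80000 nM, between 30000 nM and 200000 nM.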

Compound 4, half-maximal inhibitory concentration: 50200 nM
Compound 4: the middle estimate sits 1.6-fold (0.20 log units) above what was measured; the measured number falls inside the stated range.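

In this assay, nitro in place of trifluoromethyl gave an at least 1.9-fold lower number from compound 1 to compound 4 (0.29 log units; that floor lies within the scatter). Set beside the earlier step, this shows a lower number on both cores as far as the limit allows, but it does not fix the size of the change on either one: the same change on two cores in this assay, an at least 1.5-fold lower number (0.18 log units; that floor lies within the scatter) from compound 2 to compound 3 and an at least 1.9-fold lower number (0.29 log units; that floor lies within the scatter) from compound 1 to compound 4; the limit leaves it open whether they differ. Both steps start from a limit and both floors lie within the usual scatter, so the data do not show that the change carries from one core to the other with a particular size: the limit of > 100000 nM in this assay, at which 2 of the 4 values shown sit.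

The compounds shown leave open whether another group on that aromatic carbon, such as an amine or a carboxylic acid, would give a lower number. They also leave open what a longer chain in place of the benzyl group would do.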